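Methyl on the Aromatic Oxygen of Compound 2

The source may hold more compounds than are shown below. What is called first, only, known or untested is meant among the compounds shown, and "the series" means these compounds.

Of the compounds shown here, three have so far been tested in a functional assay on K562 cells (Homo sapiens) for cytotoxicity, read by MTT assay, with a stated time of 72 h; on this read-out higher numbers stand for weaker inhibition and lower numbers for stronger inhibition. Compound 1, `COc1ccc(C(=O)O[C@H]2CC(C)=C[C@H](O)[C@@]3(C)[C@@H](OC(C)=O)C[C@@](O)(C(C)C)[C@H]23)cc1`, gives 48200 nM in this assay. Compound 2, `CC1=C[C@H](OC(=O)c2ccc(O)cc2)[C@@H]2[C@](C)(CC[C@@]2(O)C(C)C)CC1=O`, reaches only the limit of this assay, > 100000 nM, so no number is known for it. Compound 3, `C=C1C[C@H](OC(=O)c2ccc(O)cc2)[C@@H]2[C@](C)(CC[C@@]2(O)C(C)C)C[C@@H]1O`, also stands at a limit, > 100000 nM. Compound 2 thus rests where two of the three values sit, (the limit of > 100000 nM in this assay, at which 2 of the 3 values shown sit), and compound 1 alone supplies a number. No two of these compounds differ in a single place, so no measured step is available to lean on.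

Compound 4, `COc1ccc(C(=O)O[C@H]2C=C(C)C(=O)C[C@@]3(C)CC[C@@](O)(C(C)C)[C@H]23)cc1`, is the compound still to be measured. It differs from compound 2 in one place: methyl in place of hydrogen on an oxygen on an aromatic ring. Compound 1 carries the same 4-methoxyphenyl group and gives 48200 nM, but its core differs from that of compound 2 in several places, so it only shows that a compound with this group can return a number in this assay.

The step is expected to be modest, an at least 1.2-fold lower number from compound 2 to compound 4 (0.09 log units; that floor lies within the scatter), with a real chance that the assay again reports only a limit. Compound 4 is therefore estimated at 80000 nM, with a range from 30000 nM to 200000 nM.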

Compound 4, half-maximal inhibitory concentration: > 100000 nM
Compound 4: only a limit was reported; the forecaster's own chance of this, stated with the estimate: 50%; middle value at least 1.2-fold (0.09 log units) from the limit.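

In this assay compound 4 gives > 100000 nM, which is a limit and not a number. Going by these compounds alone, compound 2 also gives only a limit, so no step between compound 2 and compound 4 can be read. The compounds shown leave open whether 4-methoxyphenyl in place of 4-hydroxyphenyl changes the value on this core at all.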